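Series notes: aryl swap on the amide-type nitrogen

The source may hold more compounds than are shown below. What is called first, only, known or untested is meant among the compounds shown, and "the series" means these compounds.

Measured so far:
compound 1 `COc1ccc(C)cc1NC(=S)N/N=C/c1ccc2ccccc2n1`: > 100000 nM
compound 2 `NC(=S)N/N=C/c1ccc2cccnc2n1`: > 100000 nM
compound 3 `S=C(N/N=C/c1ccc2ccccc2n1)Nc1cccc(Br)c1`: 53800 nM

In a functional assay on HL-60 cells (Homo sapiens) for antiproliferative activity, read by sulforhodamine B assay, with a stated time of 72 h (a higher number here means a weaker inhibitor, a lower number a stronger inhibitor), compound 1 gives > 100000 nM, which is a limit of the assay and not a number. Compound 2 likewise gives > 100000 nM, again a limit. Going by the values given here, compound 3 gives 53800 nM, the only numerical value in the set; the other two values sit at the limit of > 100000 nM in this assay, at which 2 of the 3 values shown sit. Among the compounds with values here, no step between measured compounds can be computed, so no measured pair anchors the next change.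

Compound 4 `COc1ccc(NC(=S)N/N=C/c2ccc3ccccc3n2)cc1` is not yet measured; it differs from compound 3 by 4-methoxyphenyl in place of 3-bromophenyl on an amide-type nitrogen. With two of three values at the limit, a step beyond scatter toward weaker inhibition is expected. Compound 4 is estimated at 90000 nM (range 30000 nM to 300000 nM). The expected step is a 1.7-fold higher number from compound 3 to compound 4 (0.22 log units; within the scatter), with a real chance the assay again reports only a limit.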

Compound 4, half-maximal inhibitory concentration: 43800 nM
For compound 4 the middle estimate is 2.1-fold (0.31 log units) above the measured one, and the stated range covers the measured number.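

In this assay, 4-methoxyphenyl in place of 3-bromophenyl on an amide-type nitrogen gives a 1.2-fold lower number from compound 3 to compound 4 (0.09 log units; within the scatter), so this aryl swap does not separate the two compounds. Compound 4, at 43800 nM, adds a second numerical value, and this position now has a measured pair. Compound 1 and compound 2 remain at a limit of the assay: the limit of > 100000 nM in this assay, at which 2 of the 4 values shown sit.

Still open, from the compounds shown here alone, is whether a phenyl group carrying an amine or a carboxylic acid at this nitrogen would move the number beyond the scatter. The same question holds for a longer alkyl chain in place of the aryl group.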